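Trifluoromethyl for methoxy, tried on a second core

The source may report more compounds than this note shows. Statements on the series, on what has been measured and on what is new or still open speak of the compounds shown alone.

Compound 1 `CCCCc1ccc2[nH]c(-c3ccc(OC)cc3)c(/C=N/NC(=O)c3ccccc3)c2c1` gives 32 nM in a functional assay on MDA-MB-231 cells (Homo sapiens) for antiproliferative activity, with a stated time of 4 days; a lower number here means a stronger inhibitor, a higher number a weaker inhibitor. Compound 2 `CCCCc1ccc2[nH]c(-c3ccc(C(F)(F)F)cc3)c(/C=N/NC(=O)c3ccccc3)c2c1` carries the change trifluoromethyl in place of methoxy on an aromatic carbon and gives 300 nM, so the step of a 9.4-fold higher number from compound 1 to compound 2 (0.97 log units; beyond the scatter) is a clear loss. Compound 3 `CCCCc1ccc2[nH]c(-c3ccc(OC)cc3)c(/C=N/NC(=O)c3cccnc3)c2c1` differs from compound 1 by pyridin-3-yl in place of phenyl on a carbonyl carbon; compound 3 gives 35 nM, and the step of a 1.1-fold higher number from compound 1 to compound 3 (0.04 log units; within the scatter) shows that this exchange alone does not move the number.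

Compound 4 `CCCCc1ccc2[nH]c(-c3ccc(C(F)(F)F)cc3)c(/C=N/NC(=O)c3cccnc3)c2c1` is not yet measured. It differs from compound 3 by trifluoromethyl in place of methoxy on an aromatic carbon. Within the data shown here, this is the same change as the one from compound 1 to compound 2, made here on the core of compound 3; the two cores differ only in the way just told for compound 3 against compound 1, and the place of the exchange is the same in both pairs.

For compound 4 the expected step is a 9.4-fold higher number from compound 3 to compound 4 (0.97 log units; beyond the scatter), about as large as the step of a 9.4-fold higher number from compound 1 to compound 2 (0.97 log units; beyond the scatter), because the step of a 1.1-fold higher number from compound 1 to compound 3 (0.04 log units; within the scatter) lies within the scatter and so gives no sign that the second core would carry the exchange differently. Compound 4 is therefore estimated at 330 nM, with the likely range 150 nM to 750 nM.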

Compound 4, half-maximal inhibitory concentration: 97 nM
Compound 4: the middle estimate sits 3.4-fold (0.53 log units) above what was measured; the measured number lies below the stated range.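

On the core of compound 3, trifluoromethyl in place of methoxy still raises the number in this assay, but the step is smaller, a 2.8-fold higher number from compound 3 to compound 4 (0.44 log units; beyond the scatter), and the two steps for this exchange differ in size: the same change on two cores in this assay, a 9.4-fold higher number (0.97 log units; beyond the scatter) from compound 1 to compound 2 and a 2.8-fold higher number (0.44 log units; beyond the scatter) from compound 3 to compound 4, 3.4-fold (0.53 log units) apart, beyond the scatter of two such steps. Read the other way, pyridin-3-yl in place of phenyl leaves the number unchanged within the scatter with methoxy present, yet with trifluoromethyl present it gives a 3.1-fold lower number from compound 2 to compound 4 (0.49 log units; beyond the scatter), so the two exchanges do not act independently in these compounds: the same change on two cores in this assay, a 1.1-fold higher number (0.04 log units; within the scatter) from compound 1 to compound 3 and a 3.1-fold lower number (0.49 log units; beyond the scatter) from compound 2 to compound 4, 3.4-fold (0.53 log units) apart, beyond the scatter of two such steps. The direction of the trifluoromethyl step carries from one core to the other while its size does not, but four compounds forming one square of two exchanges show neither why this is so nor how general it is.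

Still open, on these data alone, is whether the same dependence appears with chlorine or a nitrile in place of trifluoromethyl, or with a furan ring in place of pyridin-3-yl on the carbonyl. Also open, as far as these compounds go, is whether it survives a shorter chain or an amine in place of the butyl chain.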